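Series notes: aryl replacement on the shared core

The source may hold more compounds than are shown below. What is called first, only, known or untested is meant among the compounds shown, and "the series" means these compounds.

Measured so far:
compound 1, `Brc1cn2ccnc2c(-c2ccc3ncn(C4CCCCC4)c3c2)n1`: 26.8%
compound 2, `Cc1cccc(-c2cn3ccnc3c(-c3ccc4ncn(Cc5ccccc5)c4c3)n2)c1`: 11%

In a functional assay on SR cells (Homo sapiens) for inhibition, read by sulforhodamine B assay, with a stated time of 48 h, tested at 10 uM (a lower number here means less inhibition, a higher number more inhibition at the concentration tested (going by the name of the read-out)), compound 2 gives 11%, the lower of the two numbers. Compound 1 gives 26.8%, a higher value, and the gap lies beyond the usual scatter. Compound 3, `c1ccc(Cn2cnc3ccc(-c4nc(-c5cccc6ccccc56)cn5ccnc45)cc32)cc1`, differs from compound 2 by naphthalen-1-yl in place of 3-methylphenyl on an aromatic carbon. Within the data shown here, no measured pair shows this change, so only a small step is expected, in either direction. The estimate for compound 3 in this assay is 15%, between 2% and 38%. The expected step of a number 4 percentage points higher from compound 2 to compound 3 (within the scatter) is thus thought to stay within the scatter.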

Compound 3, a percentage reported as inhibition, at one concentration (the size of the read-out at that concentration, not a potency): 12.4%
For compound 3 the middle estimate is 2.6 percentage points above the measured one; the measured number falls inside the stated range.
By their numbers in this assay, from the lowest: compounds 2 and 3 (each within the scatter of the next); then compound 1.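

In this assay, among these compounds, naphthalen-1-yl in place of 3-methylphenyl on an aromatic carbon gives a number 1.4 percentage points higher from compound 2 to compound 3 (within the scatter), the first one-place comparison. At this position, the added six-membered aromatic ring therefore leaves the read-out within the scatter. Nothing on hand explains this result. Compound 1 differs from compound 2 and compound 3 in more than one place, so it does not inform this comparison. From the compounds shown here alone, whether an amine or a carboxylic acid on an aryl group at this position would move the read-out beyond the scatter remains open.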